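A few compounds are considered here, and "the series" means these few. Any claim that something is new, unique, unknown or untested is made for them only; others in the source may bear on it.

Measured so far in a functional assay on A549 cells (Homo sapiens) for antiproliferative activity, read by MTT assay, with a stated time of 48 h; on this read-out lower numbers stand for stronger inhibition and higher numbers for weaker inhibition:

compound 1, `N#CC1=C(N)Oc2c(c3nc4ccccc4nc3c3ccccc23)C12C(=O)N(Cc1cnnn1-c1ccc(Cl)cc1)c1ccccc12`: > 50000 nM, a limit of the assay
compound 2, `CCOc1ccc(-n2nncc2CN2C(=O)C3(C(C#N)=C(N)Oc4c3c3nc5ccccc5nc3c3ccccc43)c3ccccc32)cc1`: 25200 nM
compound 3, `N#CC1=C(N)Oc2c(c3nc4ccccc4nc3c3ccccc23)C12C(=O)N(Cc1cnnn1-c1ccc(N)cc1)c1ccccc12`: > 50000 nM, a limit of the assay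

Compound 1 stands only at a limit in this assay, so its position among the three is known only as a bound. Compound 3 is also reported as a limit, and the two together give (the limit of > 50000 nM in this assay, at which 2 of the 3 values shown sit). Within the data shown here, compound 2 is the single compound with a number. The steps read: an at least 1.9-fold lower number from compound 1 to compound 2 (0.29 log units; that floor lies within the scatter); a step that the two limits leave unreadable from compound 1 to compound 3; an at least 1.9-fold higher number from compound 2 to compound 3 (0.29 log units; that floor lies within the scatter). None of these steps is shown to lie beyond the scatter, and the two limits leave the series flat within what can be read.

Compound 4, `CC(=O)Nc1ccc(-n2nncc2CN2C(=O)C3(C(C#N)=C(N)Oc4c3c3nc5ccccc5nc3c3ccccc43)c3ccccc32)cc1`, differs from compound 1 by acetamido in place of chloro on an aromatic carbon. Among the measured compounds shown here, the steps that bear on it are the change to ethoxy and the change to amino at the same aromatic carbon, neither of which shows a readable movement. For compound 4 the expectation is therefore no step beyond the scatter, most likely a value again reported as a limit. Compound 4 is estimated at 50000 nM, with a range from 20000 nM to 120000 nM, which means an expected step of a number no higher from compound 1 to compound 4 (the limit leaves the size open).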

Compound 4, half-maximal inhibitory concentration: > 50000 nM
Compound 4: no number, only a limit (the forecaster's own chance of this, stated with the estimate: 65%); the middle value lies on the limit itself.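

In this assay, acetylating the amino group of compound 3 does not turn the limit into a number at this aromatic carbon, even with the acetamido group bringing in a hydrogen-bond donor and a hydrogen-bond acceptor that chloro lacks. Compound 4 is reported only as a limit of the assay, > 50000 nM. Against the one compound with a number, the change from ethoxy to acetamido reads as an at least 1.9-fold higher number from compound 2 to compound 4 (0.29 log units; that floor lies within the scatter), while the steps from compound 1 and from compound 3 to compound 4 cannot be read, and the series still rests on a single number: the limit of > 50000 nM in this assay, at which 3 of the 4 values shown sit.

Whether compound 2 truly differs from compound 1, compound 3 and compound 4 stays unresolved, as does any order among those three compounds at the limit. A longer alkoxy chain such as propoxy, a carboxylic acid or a dimethylamino group on this aromatic carbon would show whether any substituent at this place gives a value clearly separated from the limit.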